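Fluoro Added to the Anilino Group: Compound 4 Expected

The compounds below may be only part of what the source reports. "The series", "measured", "known", "first", "only" and "open" are said of these compounds alone.

Compound 1 `O=C(Nc1ccccc1)N1c2ccnn2CC1c1ccccc1`: > 1000 nM
Compound 2 `O=C(Nc1ccc(F)cc1)N1c2ccnn2CC1c1ccccc1`: > 1000 nM
Compound 3 `CCOC(=O)c1cnn2c1N(C(=O)Nc1ccccc1)C(c1ccccc1)C2`: > 1000 nM

Of the compounds shown here, three have been measured in a functional assay on cells (Neutrophil, Homo sapiens) for inhibition, with a stated time of 10 min; a higher number here means a weaker inhibitor, a lower number a stronger inhibitor. For compound 1 the result > 1000 nM is a limit of the assay and not a number. Compound 2 likewise gives > 1000 nM, again a limit. Compound 3 gives > 1000 nM, also a limit. The change from compound 1 to compound 2 is fluoro in place of hydrogen on an aromatic carbon; the resulting step that the two limits leave unreadable from compound 1 to compound 2 cannot be read because of the limit of > 1000 nM in this assay, at which 3 of the 3 values shown sit. The two cores differ by ethoxycarbonyl in place of hydrogen on an aromatic carbon, and that step, a step that the two limits leave unreadable from compound 1 to compound 3, is equally unreadable because of the limit of > 1000 nM in this assay, at which 3 of the 3 values shown sit.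

Compound 4 `CCOC(=O)c1cnn2c1N(C(=O)Nc1ccccc1F)C(c1ccccc1)C2` has not yet been measured in this assay. It differs from compound 3 by fluoro in place of hydrogen on an aromatic carbon. This is the same kind of change as that from compound 1 to compound 2, though not the same: in compound 4 the fluoro sits ortho to a large group, whereas in compound 2 it sits para to a large group. With every measured value sitting at the limit, no readable step exists from which a number could be carried over. The step from compound 3 to compound 4 is therefore expected to be small, near a step that the limit leaves unreadable from compound 3 to compound 4, because the limit of > 1000 nM in this assay, at which 3 of the 3 values shown sit, offers no sign of movement. Compound 4 is estimated at 3000 nM, most probably reported once more only as a limit, within an expected range from 700 nM to 20000 nM.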

Compound 4, half-maximal inhibitory concentration: 7.5 nM
Compound 4: middle estimate off by 400-fold (2.60 log units), on the high side, outside the stated range (below it).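

In this assay, fluoro in place of hydrogen on an aromatic carbon, ortho to a large group, gives an at least 130-fold lower number from compound 3 to compound 4 (2.12 log units; beyond the scatter), so on the core bearing the ethoxycarbonyl group, the change from phenyl to 2-fluorophenyl has a large effect on the read-out, though this is a single example on a single core. Compound 3 gives > 1000 nM, which is a limit of the assay and not a number. The result does not show that the change carries from one core to another, and the earlier fluoro and ethoxycarbonyl steps from compound 1 give no help, because neither of them can be read: the limit of > 1000 nM in this assay, at which 3 of the 4 values shown sit.

From the compounds shown here alone, whether 2-fluorophenyl on the core of compound 1, without the ethoxycarbonyl group, would give a step of similar size remains open, and so does how much of the result of compound 4 depends on that ester. Also open, going by these compounds, is how other groups in the same place on the anilino ring, such as chloro, methoxy or a carboxylic acid, would compare with fluoro, and whether a primary amide or a nitrile could stand in for the ethoxycarbonyl group.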